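A few compounds are considered here, and "the series" means these few. Any claim that something is new, unique, unknown or untested is made for them only; others in the source may bear on it.

Of the compounds shown here, three built on one shared core have been measured in a functional assay on CHO cells with adenosine receptor A1 (Homo sapiens) as the target, read by cAMP accumulation and immunoassay, with a stated time of 6 min, tested at 1 uM; on this read-out lower numbers stand for a stronger effect and higher numbers for a weaker effect at the one concentration tested. Compound 1, `CC(C)N1CCN(Cc2csc(N)c2C(=O)c2ccc(Cl)cc2)CC1`, gives 7.3%. Compound 2, `COc1ccc(N2CCN(Cc3csc(N)c3C(=O)c3ccc(Cl)cc3)CC2)cc1`, gives -15%. Compound 3, `Nc1scc(CN2CCN(c3ccc([N+](=O)[O-])cc3)CC2)c1C(=O)c1ccc(Cl)cc1`, gives -8.3%. On these numbers compound 3 stands second highest of the three: its nearest neighbour is compound 2, set apart from it by a number 6.7 percentage points higher from compound 2 to compound 3 (within the scatter), and its furthest is compound 1, set apart by a number 15.6 percentage points lower from compound 1 to compound 3 (beyond the scatter). Replacing the isopropyl on the ring nitrogen by an aromatic group produced a number 22.3 percentage points lower from compound 1 to compound 2 (beyond the scatter) and a number 15.6 percentage points lower from compound 1 to compound 3 (beyond the scatter), whereas swapping one group on that aromatic ring for another produced only a number 6.7 percentage points higher from compound 2 to compound 3 (within the scatter).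

The next compound, compound 4, `Nc1scc(CN2CCN(c3cccc(C(F)(F)F)c3)CC2)c1C(=O)c1ccc(Cl)cc1`, differs from compound 3 in a single place: 3-(trifluoromethyl)phenyl in place of 4-nitrophenyl on an amine nitrogen in a ring. This is once more a swap of one substituent on the aromatic ring for another, the same kind of change that gave a number 6.7 percentage points higher from compound 2 to compound 3 (within the scatter), a step within the scatter. The steps that replaced the isopropyl do not bear directly on it, since the aromatic ring is already in place in compound 3. No movement beyond the scatter is therefore expected in this assay. For compound 4 the expected value is -8%, with a range from -25% to 10%. That estimate amounts to an expected step of a number 0.3 percentage points higher from compound 3 to compound 4 (within the scatter).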

Compound 4, a percentage reported as activity, at one concentration (the size of the read-out at that concentration, not a potency): -72%
Compound 4: middle estimate off by 64 percentage points, on the high side, and the stated range ends above it.
By their numbers in this assay, from the lowest: compound 4; then compounds 2 and 3 (each within the scatter of the next); then compound 1.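

Swapping one substituent on the aromatic ring for another had looked nearly silent in this assay and the earlier compounds gave no sign of how sensitive this position is: 3-(trifluoromethyl)phenyl in place of 4-nitrophenyl gives a number 63.7 percentage points lower from compound 3 to compound 4 (beyond the scatter) and in place of 4-methoxyphenyl it gives a number 57 percentage points lower from compound 2 to compound 4 (beyond the scatter) at the one concentration tested. Among the compounds shown here, measured against the isopropyl the change comes to a number 79.3 percentage points lower from compound 1 to compound 4 (beyond the scatter) and far outruns the earlier steps from that group, so on these compounds an aromatic ring on the ring nitrogen is not enough by itself, and what that ring carries decides how large the effect is. Nothing measured here explains why this group behaves so differently from the other two.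

The 3-(trifluoromethyl)phenyl group differs from the 4-nitrophenyl and 4-methoxyphenyl groups both in its substituent and in the number of that substituent's place on the ring, so the compounds shown cannot tell whether the trifluoromethyl itself or its place carries the step. On these data alone, a chloro or methyl group at that same place on the aromatic ring would help to separate the two, and with a single concentration per compound these readings show only a stronger or weaker effect at that concentration, so how the compounds compare at other concentrations also stays open.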